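The source may report more compounds than this note shows. Statements on the series, on what has been measured and on what is new or still open speak of the compounds shown alone.

Compound 1 `CCCC(=O)N[C@@H](C)C(=O)N(C)/N=N/c1ccc(C#N)cc1`: 1.1 h
Compound 2 `CCC(=O)N[C@@H](C)C(=O)N(C)/N=N/c1ccc(C#N)cc1`: 1.3 h
Compound 3 `C[C@H](NC(=O)c1ccccc1)C(=O)N(C)/N=N/c1ccc(C#N)cc1`: 1.6 h

These three compounds share one core and differ only in the group attached to a carbonyl carbon of the amide on the side chain. In an ADME assay on a cell-free system (plasma, Homo sapiens) for metabolic stability, read by HPLC (on this read-out lower numbers stand for a shorter-lived compound and higher numbers for a longer-lived compound), compound 2 sits in the middle of the three numbers, with compound 1 on one side, a 1.2-fold higher number from compound 1 to compound 2 (0.07 log units; within the scatter), and compound 3 on the other, a 1.2-fold higher number from compound 2 to compound 3 (0.09 log units; within the scatter). Neither step reaches beyond the scatter, so the three measurements are best read as one common level.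

Compound 4 `CC(=O)NCC(=O)N(C)/N=N/c1ccc(C#N)cc1` has not yet been measured in this assay. Relative to compound 2 the change is a group of 5 heavy atoms (3 carbon, 1 nitrogen, 1 oxygen; no ring) in place of a group of 7 heavy atoms (5 carbon, 1 nitrogen, 1 oxygen; no ring), on a carbonyl carbon. Going by the values given here, the steps that bear on it are those already seen at this position: swapping hydrogen for methyl on the chain between compound 1 and compound 2, and swapping the group on the carbonyl carbon between compound 2 and compound 3. Both stayed within the scatter. The step to compound 4 is therefore expected to stay within the scatter as well, with no clear direction, a 1.1-fold lower number from compound 2 to compound 4 (0.03 log units; within the scatter). Compound 4 is estimated at 1.2 h, with a range from 0.6 h to 2.4 h.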

Compound 4, half-life in the plasma assay: 1.2 h
Compound 4: the middle estimate sits on the measured number at the digits printed; the measured number falls inside the stated range.
By their numbers in the plasma assay, from the lowest: compounds 1, 4, 2 and 3 (each within the scatter of the next).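

In the plasma assay, the swap to acetamidomethyl leaves the number within the scatter, a 1.1-fold lower number from compound 2 to compound 4 (0.03 log units; within the scatter), even though the group that leaves carries a defined stereocentre and acetamidomethyl carries none, something compounds 1, 2 and 3 could not show because all three keep that stereocentre. In a physicochemical assay for lipophilicity, read by HPLC, in phosphate buffer, measured as octanol-water partition, at pH 7.4 (on this read-out lower numbers stand for lower lipophilicity and higher numbers for higher lipophilicity), compound 2 gives 1.87 and compound 4 gives 1.1, so the same swap shows up clearly there, a number 0.77 log units lower from compound 2 to compound 4 (beyond the scatter). At this place on a carbonyl carbon, then, lipophilicity can shift beyond the scatter while the plasma half-life stays within it: the measured partition coefficient of compound 2, 1.87, and of compound 4, 1.1, a number 0.77 log units lower (beyond the scatter)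

Still open is how the plasma assay and the physicochemical assay would respond to a group carrying an amine or a carboxylic acid at this place, since every group shown here has no net charge. The swap also shortens the group and removes the stereocentre in a single step, so the compounds shown cannot tell which of these two differences goes with the lower partition coefficient.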